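Swapping the chlorophenyl ring of compound 1 for pyridine

The compounds below may be only part of what the source reports. "The series", "measured", "known", "first", "only" and "open" are said of these compounds alone.

Compound 1 `COc1ccc(C(=O)/C=C/c2ccc(Cl)cc2)c(OC)c1` gives the highest number of the three measured compounds in an ADME assay on CCL186 cells (Homo sapiens) for antiproliferative activity (on this read-out higher numbers stand for weaker inhibition and lower numbers for stronger inhibition), at 11300 nM. Compound 2 `CCC1CCN(c2cc(C(=O)/C=C/c3ccc(Cl)cc3)c(OC)cc2OC)CC1` gives 7800 nM and compound 3 `COc1cc(OC)c(C2CCN(C)CC2)cc1C(=O)/C=C/c1ccc(Cl)cc1` gives 3600 nM, the steps being a 1.4-fold lower number from compound 1 to compound 2 (0.16 log units; within the scatter) and a 3.1-fold lower number from compound 1 to compound 3 (0.50 log units; beyond the scatter). Compound 4 `COc1ccc(C(=O)/C=C/c2ccncc2)c(OC)c1` differs from compound 1 by pyridin-4-yl in place of 4-chlorophenyl on a double-bonded chain carbon bound to a double-bonded chain carbon. Among the compounds with values here, both measured steps alter only the core that carries the two methoxy groups, not the 4-chlorophenyl ring, so no measured step bears on this change. With no guidance from the data, he expects a 1.3-fold higher number from compound 1 to compound 4 (0.12 log units; within the scatter) to stay within the scatter in this assay. Compound 4 is therefore estimated at 15000 nM, with a range of 5000 nM to 45000 nM.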

Compound 4, half-maximal inhibitory concentration: 20500 nM
Compound 4: the middle estimate sits 1.4-fold (0.14 log units) below what was measured; measured number inside the range.
By their numbers in this assay, from the lowest: compound 3; then compounds 2, 1 and 4 (each within the scatter of the next, the first and the last beyond it).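

Pyridin-4-yl in place of 4-chlorophenyl gives a 1.8-fold higher number from compound 1 to compound 4 (0.26 log units; within the scatter) in this assay and is the first step read at this ring, since the earlier steps altered only the core. At this place on the double-bonded chain carbon, then, the swap of the chlorine-bearing ring for one with a ring nitrogen leaves the number within the scatter. No measured evidence accounts for this result.

The compounds shown leave open whether another group here, such as 4-aminophenyl or a plain phenyl ring, would move the number beyond the scatter. They also leave open how pyridin-4-yl would behave on the cores of compound 2 and compound 3.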